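Amide to urea on the shared core: compound 3

The source may hold more compounds than are shown below. What is called first, only, known or untested is meant among the compounds shown, and "the series" means these compounds.

Two amides on the shared core have been measured in an assay on cells for displacement of a labelled ligand from adenosine receptor A1 (Homo sapiens), read by scintillation counting, with a stated time of 120 min, tested at 1 uM; a higher number here means more inhibition at the concentration tested (going by the name of the read-out), a lower number less inhibition. Compound 1 `Cc1ccc(C(=O)Nc2nccn3cc(-c4ccccc4)nc23)cc1` gives 26%. Compound 2 `O=C(Nc1nccn2cc(-c3ccccc3)nc12)c1cccnc1` gives 24%. For the measured compounds named here, the one step between them, a number 2 percentage points lower from compound 1 to compound 2 (within the scatter), leaves the core and the amide untouched and changes only the aryl group on the carbonyl carbon. On these two numbers compound 2 stands at the lower end, with compound 1 nearest, and the gap lies within the scatter.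

Compound 3 `O=C(Nc1ccccc1)Nc1nccn2cc(-c3ccccc3)nc12` is not yet measured. It differs from compound 2 by anilino in place of pyridin-3-yl on a carbonyl carbon. Going by the values given here, no measured step introduces anilino on the carbonyl carbon, so the only step with any bearing is a number 2 percentage points lower from compound 1 to compound 2 (within the scatter), which shows that exchanging the aryl group there moved the read-out by an amount within the scatter. The expected step of a number 1 percentage points higher from compound 2 to compound 3 (within the scatter) is therefore none beyond the scatter, with wider uncertainty for an untested group. Compound 3 is estimated at 25%, range 8% to 45%.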

Compound 3, a percentage reported as inhibition, at one concentration (the size of the read-out at that concentration, not a potency): 1%
Beside the measured number, compound 3's estimate is 24 percentage points above it, and the stated range ends above it.
By their numbers in this assay, from the lowest: compound 3; then compounds 2 and 1 (each within the scatter of the next).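

In this assay the group on the carbonyl carbon can clearly change the read-out: exchanging one aryl group for another gave no step beyond the scatter, but anilino in place of pyridin-3-yl gives a number 23 percentage points lower from compound 2 to compound 3 (beyond the scatter). Anilino in place of 4-methylphenyl gives a matching result, a number 25 percentage points lower from compound 1 to compound 3 (beyond the scatter), so the drop appears against both amides. No available measurement accounts for the drop.

The compounds shown do not separate the urea linkage from the phenyl ring it carries, which a methylamino or benzylamino group on the carbonyl carbon would help to address. As far as these compounds go, it also remains open whether substituents such as a methoxy group or a chlorine atom on the anilino ring would alter the result.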